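A few compounds are considered here, and "the series" means these few. Any claim that something is new, unique, unknown or untested is made for them only; others in the source may bear on it.

For the measured compounds named here, in an ADME assay on HEK-293T cells (Homo sapiens) for cytotoxicity, read by MTT assay, with a stated time of 24 h (a higher number here means that more compound is tolerated, a lower number that less compound is tolerated), three compounds built on a shared core have numbers so far: compound 1 (`Cc1ccc(-c2nn(-c3ccccc3)cc2-c2nc3ccccc3n2S(=O)(=O)c2ccc(F)cc2)cc1`) gives 128000 nM, compound 2 (`Cc1ccc(-c2nn(-c3ccccc3)cc2-c2nc3ccccc3n2S(=O)(=O)c2ccc(Cl)cc2)cc1`) gives 167000 nM and compound 3 (`Cc1ccc(-c2nn(-c3ccccc3)cc2-c2nc3ccccc3n2S(=O)(=O)c2ccc(C(F)(F)F)cc2)cc1`) gives 182000 nM. Compound 2 stands level with the other two, since a 1.3-fold higher number from compound 1 to compound 2 (0.12 log units; within the scatter) and a 1.1-fold higher number from compound 2 to compound 3 (0.04 log units; within the scatter) both lie within the scatter. Compound 4 (`O=S(=O)(c1ccc(Cl)cc1)n1c(-c2cn(-c3ccccc3)nc2-c2ccc(C(F)(F)F)cc2)nc2ccccc21`) follows from compound 2 by one change: trifluoromethyl in place of methyl on an aromatic carbon. Going by the values given here, no measured step swaps a methyl. The closest ones, a 1.4-fold higher number from compound 1 to compound 3 (0.15 log units; within the scatter) and a 1.1-fold higher number from compound 2 to compound 3 (0.04 log units; within the scatter), bring in trifluoromethyl in place of a halogen and stay within the scatter, so no step beyond the scatter is expected in this assay. The expected step is a 1.0-fold higher number from compound 2 to compound 4 (0.01 log units; within the scatter). The estimate for compound 4 is 170000 nM, with an expected range from 90000 nM to 320000 nM.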

Compound 4, half-maximal cytotoxic concentration: 75300 nM
Estimate against measurement, compound 4: 2.3-fold (0.35 log units) above; the whole stated range lies above it.
By their numbers in this assay, from the lowest: compounds 4, 1, 2 and 3 (each within the scatter of the next, the first and the last beyond it).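

In this assay, going from 4-methylphenyl to 4-(trifluoromethyl)phenyl gives a 2.2-fold lower number from compound 2 to compound 4 (0.35 log units; beyond the scatter), a modest step but the first among these compounds to pass beyond the scatter. The earlier swaps among fluoro, chloro and trifluoromethyl, made at a different place on the shared core, all stayed within it, so this position shows a response that those steps did not. Nothing measured here explains the lower number. From the compounds shown here alone, it remains open whether the fall is specific to trifluoromethyl or would also follow with another group in place of methyl, such as an amine or a carboxylic acid.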